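This account rests on a few compounds, and the source may have more. Where it says the series, first, only, none or still open, it means among the compounds named here.

Measured in an ADME assay on HepG2 cells (Homo sapiens) for cytotoxicity, with a stated time of 72 h; on this read-out lower numbers stand for an effect already at smaller amounts and higher numbers for an effect only at larger amounts of compound:

Compound 1 `Cc1cc(NC(=O)Nc2ccc(C)c(Cl)c2)c2ccccc2n1` gives > 25000 nM, which is a limit of the assay.
Compound 2 `Cc1cc(NC(=O)Nc2ccc(C(=O)O)cc2)c2ccccc2n1` gives > 25000 nM, which is a limit of the assay.
Compound 3 `Cc1cc(NC(=O)Nc2ccccc2C(F)(F)F)c2ccccc2n1` gives > 25000 nM, which is a limit of the assay.

Compound 2 therefore stands at the limit of > 25000 nM in this assay, at which 3 of the 3 values shown sit, and no number inside the measured range is known for any of the three compounds. Within the data shown here, no pair among them differs in only one place, so no step between measured compounds can be stated.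

The compound still to be measured is compound 4 `Cc1cc(NC(=O)Nc2ccc(N)cc2)c2ccccc2n1`. It differs from compound 2 in one place: amino in place of carboxy on an aromatic carbon. Among the measured compounds shown here, since every value in this assay so far is a limit, the data give no measured step from which the size of this change could be read. The expectation is a step from compound 2 to compound 4 of a step that the limit leaves unreadable from compound 2 to compound 4, that is, none beyond the scatter, with the result most likely again reported as a limit. For compound 4 the estimated value in this assay is 30000 nM, with a range from 12000 nM to 80000 nM.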

Compound 4, half-maximal effective concentration: > 25000 nM
Compound 4 ended at the assay's limit; the forecaster's own chance of this, stated with the estimate: 80%; the middle value does not contradict the limit.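

In this assay compound 2 and compound 4 both sit at a limit, so no step can be read between them: the limit of > 25000 nM in this assay, at which 4 of the 4 values shown sit. The compounds shown leave open at what concentration any of them reaches a half-maximal effect, and whether exchanging carboxy for amino changes it.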